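The source may hold more compounds than are shown below. What is called first, only, known or untested is meant among the compounds shown, and "the series" means these compounds.

The measured compounds:

Compound 1 `FC(F)(F)c1ccc(-c2cn(Cc3ccccc3)nn2)cc1`: in a functional assay on B16 cells (Mus musculus) for cytotoxicity, read by MTT assay, with a stated time of 48 h (on this read-out higher numbers stand for weaker inhibition and lower numbers for stronger inhibition), compound 1 gives > 100000 nM, which is a limit of the assay and not a number.
Compound 2 `COc1ccc(-c2cn(Cc3ccccc3)nn2)cc1`: in this assay compound 2 gives > 100000 nM, again a limit of the assay.
Compound 3 `OCCCn1cc(-c2ccc(C(F)(F)F)cc2)nn1`: in this assay compound 3 gives > 100000 nM, also a limit of the assay.

Among the compounds with values here, every value so far sits at the limit of > 100000 nM in this assay, at which 3 of the 3 values shown sit, so none of the compounds has a readable potency. The change from compound 1 to compound 2 is methoxy in place of trifluoromethyl on an aromatic carbon, and its step is a step that the two limits leave unreadable from compound 1 to compound 2. The change from compound 1 to compound 3 is 2-hydroxyethyl in place of phenyl on a saturated chain carbon bound to an aromatic nitrogen, with a step that the two limits leave unreadable from compound 1 to compound 3.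

The unmeasured compound 4 `COc1ccc(-c2cn(CCCO)nn2)cc1` carries the same kind of change as compound 2 does, now made on the core of compound 3: methoxy in place of trifluoromethyl on an aromatic carbon. The two cores differ as told by 2-hydroxyethyl in place of phenyl on a saturated chain carbon bound to an aromatic nitrogen. Around the place, the change on compound 1 sits para to a large group, while on compound 3 it sits para to a group of 9 heavy atoms.

For compound 4 in this assay the step from compound 3 is expected to be a step that the limit leaves unreadable from compound 3 to compound 4, resting on a step that the two limits leave unreadable from compound 1 to compound 2, which itself could not be read. Given that compound 3 sits at a limit, compound 4 is estimated at 150000 nM, most likely again reported only as a limit of the assay.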

Compound 4, half-maximal inhibitory concentration: > 100000 nM
Compound 4: a limit, no number (the forecaster's own chance of this, stated with the estimate: 85%); the middle value is on the limit's open side.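

In this assay compound 4 gives > 100000 nM, which is a limit of the assay and not a number, so the steps to compound 4 from compound 3 and from compound 2 cannot be read: the limit of > 100000 nM in this assay, at which 4 of the 4 values shown sit.

The compounds shown leave open whether methoxy in place of trifluoromethyl, or 2-hydroxyethyl in place of phenyl, changes potency at all in this assay.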